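A few compounds are considered here, and "the series" means these few. Any claim that something is new, unique, unknown or untested is made for them only; others in the source may bear on it.

Notes on the series. Compound 1 `O=C(/C=C\Nc1ccc(F)cc1)c1nc(-c2ccc(C(F)(F)F)cc2)n2ccccc12` is the reference point. In a functional assay on A549 cells (Homo sapiens) for cytotoxicity, read by MTT assay, with a stated time of 48 h (on this read-out higher numbers stand for weaker inhibition and lower numbers for stronger inhibition), compound 1 gives > 30000 nM, which is a limit of the assay rather than a number. Among the measured compounds shown here, the only measured neighbour is compound 2 `COc1ccc(-c2nc(C(=O)/C=C\Nc3ccc(F)cc3)c3ccccn23)cc1`, which differs by methoxy in place of trifluoromethyl on an aromatic carbon. In this assay compound 2 gives > 30000 nM, again a limit. The step that the two limits leave unreadable from compound 1 to compound 2 therefore cannot be read; both values sit at the limit of > 30000 nM in this assay, at which 2 of the 2 values shown sit.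

Compound 3 `COc1ccc(N/C=C\C(=O)c2nc(-c3ccc(C(F)(F)F)cc3)n3ccccc23)cc1` differs from compound 1 by methoxy in place of fluoro on an aromatic carbon. No measured step touches this exchange, and the single step shown, a step that the two limits leave unreadable from compound 1 to compound 2, is itself unreadable, so nothing on the numbers fixes a size or a direction for the change in this assay. Since compound 1 stands only at a limit, the expectation for compound 3 is a step of a number no higher from compound 1 to compound 3 (the limit leaves the size open) that amounts to no readable movement. Compound 3 is accordingly estimated at 30000 nM, with a range of 10000 nM to 100000 nM, and it is expected that the assay most likely again reports only a limit.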

Compound 3, half-maximal inhibitory concentration: 21800 nM
Estimate against measurement, compound 3: 1.4-fold (0.14 log units) above; measured number inside the range.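

Among the compounds shown here, the change from (4-fluorophenyl)amino to (4-methoxyphenyl)amino gives the first value that is a number and not a limit: in this assay compound 3 gives 21800 nM. The exchange of fluoro for methoxy at this position reads as an at least 1.3-fold lower number from compound 1 to compound 3 (0.13 log units; that floor lies within the scatter), so the step has a floor but no upper bound, and that floor alone does not establish a change beyond the usual scatter. The number for compound 3 gives later comparisons at this position a readable reference, while the other values in the series remain at the ceiling: the limit of > 30000 nM in this assay, at which 2 of the 3 values shown sit.

The compounds shown leave open whether the same exchange would have a readable effect with methoxy in place of trifluoromethyl at the other aromatic position, the substitution carried by compound 2. They also leave open how an amine, a hydroxyl group, a carboxylic acid or a longer alkoxy chain would read in place of methoxy on this six-membered aromatic ring, and whether any such group would move the number clearly beyond the scatter.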